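This account rests on a few compounds, and the source may have more. Where it says the series, first, only, none or still open, it means among the compounds named here.

Series notes. Compound 1 `O=C(Nc1cccc(-n2cc(-c3ccncc3)c(-c3ccc(Cl)c(O)c3)n2)c1)Nc1cc(C(F)(F)F)cc(C(F)(F)F)c1` carries a diaryl urea on the shared core; in a functional assay on PC-3 cells (Homo sapiens) for inhibition, read by sulforhodamine B assay, with a stated time of 48 h (a lower number here means a stronger inhibitor, a higher number a weaker inhibitor), compound 1 gives 320 nM. Compound 2 `COc1cc(-c2nn(-c3cccc(NC(=O)Nc4ccc(Cl)c(C(F)(F)F)c4)c3)cc2-c2ccncc2)ccc1Cl` carries a methoxy in place of the hydroxyl of compound 1 together with a different urea terminus; in this assay compound 2 gives 690 nM. Compound 3 `COc1cc(-c2nn(-c3cccc(NC(=O)c4ccccc4)c3)cc2-c2ccncc2)ccc1Cl` is the benzamide counterpart of compound 2; in this assay compound 3 gives 430 nM. The gap between compound 1 and compound 3 lies within the scatter, whereas compound 2 sits beyond the scatter on the higher side of compound 1. Going by the values given here, the only single-point step available, a 1.6-fold lower number from compound 2 to compound 3 (0.21 log units; within the scatter), takes away the whole substituted aryl amino terminus of the urea and moves the number only within the scatter.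

Compound 4 `O=C(Nc1cccc(-n2cc(-c3ccncc3)c(-c3ccc(Cl)c(O)c3)n2)c1)Nc1cccc(C(F)(F)F)c1` is not yet measured. It differs from compound 1 by hydrogen in place of trifluoromethyl on an aromatic carbon. Among the compounds with values here, no measured step touches this position; the nearest analogy is the step from compound 2 to compound 3, in which a much larger part of the terminal group was exchanged with a shift inside the scatter. The expectation for this assay is therefore a step within the scatter, a 1.4-fold higher number from compound 1 to compound 4 (0.15 log units; within the scatter), with no preferred direction. The number expected for compound 4 is 450 nM, with a range from 200 nM to 1000 nM.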

Compound 4, half-maximal inhibitory concentration: 950 nM
The estimate for compound 4 lay 2.1-fold (0.32 log units) below the measured number; measured number inside the range.
By their numbers in this assay, from the lowest: compounds 1, 3, 2 and 4 (each within the scatter of the next, the first and the last beyond it).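

Working from this assay, the position carrying the second trifluoromethyl on the urea terminus turns out not to be indifferent: hydrogen in its place gives a 3.0-fold higher number from compound 1 to compound 4 (0.47 log units; beyond the scatter). Going by these compounds alone, this is the first step to go beyond the scatter, whereas the only earlier step, a 1.6-fold lower number from compound 2 to compound 3 (0.21 log units; within the scatter), took away the whole substituted aryl amino terminus on the methoxy background and stayed within it, so the size of an exchange at the terminus does not by itself set the size of the shift across these two pairs. Nothing at hand explains the shift or tells why the two steps differ.

Open, on these data alone, is whether a nitrile or a methyl group on this aromatic carbon would keep the number close to that of compound 1 at 320 nM or leave it close to that of compound 4 at 950 nM. Also open, as far as these compounds go, is whether the loss of trifluoromethyl at this position carries the same weight when methoxy stands in place of the hydroxyl on the shared core.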